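The source may report more compounds than this note shows. Statements on the series, on what has been measured and on what is new or still open speak of the compounds shown alone.

Compound 2 `CC(C)c1n[nH]c2c(NCc3ccc(-c4ccccn4)cc3)nc(SCC(N)=O)nc12` gives 192 nM in a functional assay on HT cells (Homo sapiens) for antiproliferative activity, read by fluorescence, with a stated time of 72 h; a higher number here means a weaker inhibitor of growth, a lower number a stronger inhibitor of growth; compound 3 `CC(C)c1n[nH]c2c(NCc3ccc(-c4ccccn4)cc3)nc(SCCn3ccnc3)nc12` at 155 nM lies within the scatter of it, and compound 1 `CC(C)c1n[nH]c2c(NCc3ccc(-c4ccccn4)cc3)nc(SCC(O)CN)nc12` at 55 nM lies beyond it. The measured steps of a 3.5-fold higher number from compound 1 to compound 2 (0.54 log units; beyond the scatter) and a 2.8-fold higher number from compound 1 to compound 3 (0.45 log units; beyond the scatter) are modest, and a 1.2-fold lower number from compound 2 to compound 3 (0.09 log units; within the scatter) is within the scatter. Compound 4 `CC(C)c1n[nH]c2c(NCc3ccc(-c4ccccn4)cc3)nc(S)nc12` differs from compound 2 by hydrogen in place of carbamoylmethyl on a sulfur. Within the data shown here, no measured step removes the whole chain on the sulfur; the three steps only exchange its terminus, and every terminus tried keeps the number within a narrow band. A step toward a higher number in this assay, beyond the scatter and of uncertain size, is therefore expected for compound 4. Compound 4 is estimated at 700 nM, range 150 nM to 3500 nM. The expected step is a 3.6-fold higher number from compound 2 to compound 4 (0.56 log units; beyond the scatter).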

Compound 4, concentration for 50% growth inhibition: 2760 nM
Beside the measured number, compound 4's estimate is 3.9-fold (0.60 log units) below it; the measured number falls inside the stated range.
By their numbers in this assay, from the lowest: compound 1; then compounds 3 and 2 (each within the scatter of the next); then compound 4.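

In this assay, removing the whole chain from the sulfur weighs far more than any exchange of its terminus: the steps are a 14-fold higher number from compound 2 to compound 4 (1.16 log units; beyond the scatter), an 18-fold higher number from compound 3 to compound 4 (1.25 log units; beyond the scatter) and a 50-fold higher number from compound 1 to compound 4 (1.70 log units; beyond the scatter), all large. The earlier steps shown here showed only that the three termini stay close together; these show that the number depends on having a chain on this sulfur at all. Nothing available accounts for the size of this change.

Still open, going by these compounds, is how little of the chain suffices, as a lone methyl on the sulfur would show. Also open, on these data alone, is whether a longer chain or a terminal carboxylic acid would keep the number near that of compound 1.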